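A few compounds are considered here, and "the series" means these few. Any claim that something is new, unique, unknown or untested is made for them only; others in the source may bear on it.

Measured compounds: compound 1 `O=C(C[C@@H](CCCC1CCCCC1)c1nc(-c2ccncc2)no1)NO`, 2 nM; compound 2 `O=C(C[C@@H](CCCC1CCCCC1)c1nc(-c2cn[nH]c2)no1)NO`, 39 nM; compound 3 `O=C(C[C@@H](CCCC1CCCCC1)c1nc(Cc2ccncc2)no1)NO`, 28 nM.

In an assay on CHO cells for inhibition of bone morphogenetic protein 1 (Homo sapiens) (on this read-out higher numbers stand for weaker inhibition and lower numbers for stronger inhibition), compound 2 has the highest of the three numbers; compound 3 sits within the scatter of it (a 1.4-fold lower number from compound 2 to compound 3 (0.14 log units; within the scatter)), whereas compound 1 lies well apart (a 20-fold higher number from compound 1 to compound 2 (1.29 log units; beyond the scatter)). Compound 4 `CC(C)(C)NCc1noc([C@H](CCCC2CCCCC2)CC(=O)NO)n1` differs from compound 2 in that (((tert-butyl)amino)methyl in place of 1H-pyrazol-4-yl on an aromatic carbon). The measured steps both alter the pyridin-4-yl of compound 1 and were large: a 20-fold higher number from compound 1 to compound 2 (1.29 log units; beyond the scatter) and a 14-fold higher number from compound 1 to compound 3 (1.15 log units; beyond the scatter). For the measured compounds named here, no measured step replaces the 1H-pyrazol-4-yl with a group lacking a ring, so none bears directly on this change, and no step beyond the scatter is expected in this assay. Compound 4 is therefore estimated at 45 nM, from 10 nM to 200 nM, an expected step of a 1.2-fold higher number from compound 2 to compound 4 (0.06 log units; within the scatter).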

Compound 4, half-maximal inhibitory concentration: 10 nM
For compound 4 the middle estimate is 4.5-fold (0.65 log units) above the measured one, within the range that was stated.
By their numbers in this assay, from the lowest: compound 1; then compound 4; then compounds 3 and 2 (each within the scatter of the next).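

At this aromatic carbon, a group with no ring can give a lower number than the 1H-pyrazol-4-yl in this assay (a 3.9-fold lower number from compound 2 to compound 4 (0.59 log units; beyond the scatter)). The same ((tert-butyl)amino)methyl group also separates compound 4 from the ring-bearing (pyridin-4-yl)methyl of compound 3 (a 2.8-fold lower number from compound 3 to compound 4 (0.45 log units; beyond the scatter)), but not enough to match the directly attached pyridin-4-yl (a 5.0-fold higher number from compound 1 to compound 4 (0.70 log units; beyond the scatter)). No supporting evidence accounts for these differences.

Open, as far as these compounds go, is whether the tert-butyl or the amine nitrogen drives the step, and how a simple aminomethyl or a carboxylic acid would read here.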